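The source may report more compounds than this note shows. Statements on the series, on what has been measured and on what is new or still open speak of the compounds shown alone.

Working notes, series of sugar-fused sultam thymidine analogues, read in a functional assay on HEL cells (Homo sapiens) for cytotoxicity, read by microscopy; on this read-out higher numbers stand for lower toxicity in this test and lower numbers for higher toxicity in this test:

- compound 1 `Cc1cn([C@@H]2O[C@H](CO[Si](C)(C)C(C)(C)C)[C@@]3(OS(=O)(=O)C=C3NCC(=O)O)[C@H]2O[Si](C)(C)C(C)(C)C)c(=O)n(C)c1=O`: 300000 nM
- compound 2 `Cc1cn([C@@H]2O[C@H](CO[Si](C)(C)C(C)(C)C)[C@@]3(OS(=O)(=O)C=C3NCC(N)=O)[C@H]2O[Si](C)(C)C(C)(C)C)c(=O)n(C)c1=O`: 16000 nM
- compound 3 `Cc1cn([C@@H]2O[C@H](CO[Si](C)(C)C(C)(C)C)[C@@]3(OS(=O)(=O)C=C3NCCC(=O)OCc3ccccc3)[C@H]2O[Si](C)(C)C(C)(C)C)c(=O)n(C)c1=O`: reported only as a limit, >= 400000 nM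

Compound 1 holds the highest of the two plain numbers; the nearest is compound 2, with a 19-fold lower number from compound 1 to compound 2 (1.27 log units; beyond the scatter). Compound 3 stands at the limit of >= 400000 nM in this assay, at which 1 of the 3 values shown sits, so its distance from compound 1 is only a floor.

Compound 4 `Cc1cn([C@@H]2O[C@H](CO[Si](C)(C)C(C)(C)C)[C@@]3(OS(=O)(=O)C=C3NCCC(N)=O)[C@H]2O[Si](C)(C)C(C)(C)C)c(=O)n(C)c1=O` differs from compound 1 in one place: carbamoylmethyl in place of carboxy on a saturated chain carbon bound to an amine nitrogen. Within the data shown here, two measured steps touch this change. Turning the acid of compound 1 into the amide of compound 2 gives a 19-fold lower number from compound 1 to compound 2 (1.27 log units; beyond the scatter), a large move toward higher toxicity. Lengthening from the amide of compound 2 to the benzyl ester of compound 3 gives an at least 25-fold higher number from compound 2 to compound 3 (1.39 log units; beyond the scatter), while from compound 1 to compound 3 the step is an at least 1.3-fold higher number from compound 1 to compound 3 (0.12 log units; that floor lies within the scatter), whose floor sits within the scatter. The amide component is therefore expected to dominate, and a lower number than compound 1 is expected for compound 4. From the compounds shown here alone, the extra chain carbon is untested on its own and is taken to soften the move. The step expected for compound 4 is a 6.0-fold lower number from compound 1 to compound 4 (0.78 log units; beyond the scatter).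

Compound 4 is thus estimated at 50000 nM, with a range from 15000 nM to 200000 nM.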

Compound 4, minimum cytotoxic concentration: >= 80000 nM
Compound 4: no number, only a limit (the forecaster's own chance of this, stated with the estimate: 10%); middle value at least 1.6-fold (0.20 log units) from the limit.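

Compound 4 is reported only as a limit: the limit of >= 80000 nM in this assay, at which 1 of the 4 values shown sits.

In this assay, carbamoylmethyl in place of carbamoyl on the saturated chain carbon bound to an amine nitrogen gives an at least 5.0-fold higher number from compound 2 to compound 4 (0.69 log units; beyond the scatter), so the amide end group alone does not carry the low number of compound 2, and the toxicity seen there is not kept once the chain is a 2-carbamoylethyl one. Among these compounds, this is the first sign that this position responds to chain length as well as to the end group, although the limit fixes only a lower bound on the size of the move, and the steps joining compound 4 to compound 1 and to compound 3 cannot be read.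

Still open, from the compounds shown here alone, is whether the amide on the chain of compound 4 differs at all from an acid, which a 2-carboxyethyl group on the same amine nitrogen would settle against compound 4 and compound 1. Also open, going by these compounds, is whether the low number of compound 2 is specific to the carbamoyl group, or would also appear with another short group such as a 2-aminoethyl chain or with a longer chain such as 3-carbamoylpropyl.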